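A few compounds are considered here, and "the series" means these few. Any claim that something is new, unique, unknown or untested is made for them only; others in the source may bear on it.

Working notes on the series. In a functional assay on MCF7 cells (Homo sapiens) for antiproliferative activity, read by sulforhodamine B assay, with a stated time of 48 h (a higher number here means a weaker inhibitor, a lower number a stronger inhibitor), compound 1 (`COc1cccc(/C=C/C(=O)C(=Cc2ccc(O)c(F)c2)C(=O)/C=C/c2cccc(OC)c2OC)c1OC`) gives 300 nM and compound 2 (`COc1cccc(/C=C/C(=O)C(=Cc2ccc(OC)c(OC)c2OC)C(=O)/C=C/c2cccc(OC)c2OC)c1OC`) gives 380 nM. Among the compounds with values here, these are the only two numbers so far, and they lie within the scatter of each other, so compound 2 cannot be separated from compound 1.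

The next structure is compound 3 (`COc1ccc(C=C(C(=O)/C=C/c2cccc(OC)c2OC)C(=O)/C=C/c2cccc(OC)c2OC)cc1O`), which differs from compound 2 as follows: 3-hydroxy-4-methoxyphenyl in place of 2,3,4-trimethoxyphenyl on a double-bonded chain carbon bound to a double-bonded chain carbon. The 2,3,4-trimethoxyphenyl group therefore gives way to 3-hydroxy-4-methoxyphenyl on the double-bonded chain carbon.

Within the data shown here, one measured step bears on this place: a 1.3-fold higher number from compound 1 to compound 2 (0.10 log units; within the scatter). That step exchanged 3-fluoro-4-hydroxyphenyl and 2,3,4-trimethoxyphenyl at the same place and stayed small. Among the measured compounds shown here, it is a single step with a different group, and no measured compound yet carries 3-hydroxy-4-methoxyphenyl, so the evidence is thin.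

On that basis, no change beyond the scatter is expected in this assay, and no direction can be assigned. The expected step is a 1.2-fold lower number from compound 2 to compound 3 (0.06 log units; within the scatter). The estimate for compound 3 is 330 nM, with an expected range of 130 nM to 800 nM.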

Compound 3, half-maximal inhibitory concentration: 310 nM
Compound 3: the middle estimate sits 1.1-fold (0.03 log units) above what was measured; the range from low to high includes it.
By their numbers in this assay, from the lowest: compounds 1, 3 and 2 (each within the scatter of the next).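

In this assay the exchange on the double-bonded chain carbon gives a 1.2-fold lower number from compound 2 to compound 3 (0.09 log units; within the scatter) and, against the fluorinated group, a 1.0-fold higher number from compound 1 to compound 3 (0.01 log units; within the scatter) while the three aryl groups at this place remain inseparable. The 2,3,4-trimethoxyphenyl group has 12 heavy atoms and 0 hydrogen-bond donors, whereas 3-hydroxy-4-methoxyphenyl has 9 heavy atoms and 1 hydrogen-bond donor, and this difference leaves no mark beyond the scatter on the number read out; compound 1, with its 3-fluoro-4-hydroxyphenyl group, does not separate from either. No measured evidence on any property of these groups is at hand to account for this flat result.

Going by these compounds, whether a group of another kind at this place, such as an aminophenyl ring, a carboxylic acid or a longer chain, would move the number beyond the scatter remains open. Also open, on these data alone, is whether the parts of the shared core that these three compounds hold constant tolerate change as readily, and whether the flat picture seen in this assay extends to any other cell line.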